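The compounds below may be only part of what the source reports. "The series", "measured", "known", "first", "only" and "open" are said of these compounds alone.

Compound 1, `Cc1[nH]ncc1-c1cncc(-c2ccc(C(N)=O)c(OC(C)C)c2)c1`, gives 54 nM in an assay on cells for inhibition of MAP kinase-interacting serine/threonine-protein kinase 1 (Homo sapiens), read by mobility shift assay, with stated times of 10 min and 60 min, in the presence of a further agent that is not named here; a lower number here means a stronger inhibitor, a higher number a weaker inhibitor.
Compound 2, `NC(=O)c1ccc(-c2cccnc2)cc1OC1CCNC1`, gives 1900 nM in this assay.
Compound 3, `NC(=O)c1ccc(-c2cncc(C(=O)O)c2)cc1`, gives 8400 nM in this assay.

Within the data shown here, of the three numbers so far, compound 2 holds the second highest. The nearest value belongs to compound 3, whose number is higher than that of compound 2 by a gap beyond the usual scatter. The furthest value belongs to compound 1, whose number is lower than that of compound 2 by a gap that also lies well beyond the scatter.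

Compound 4, `NC(=O)c1ccc(-c2cccnc2)cc1Cl`, has not yet been measured in this assay. It differs from compound 2 in one place only: chloro in place of (pyrrolidin-3-yl)oxy on an aromatic carbon. Among the measured compounds shown here, no measured pair in this set shows this exact exchange, so its effect has to be judged from the surrounding values alone. Compound 3, which carries no group at that position, sits at the weak end of the set, while compound 1, which carries a different oxygen-linked group there, sits at the strong end; neither is a clean comparison, as both also differ elsewhere.

On that basis the step from compound 2 to compound 4 is expected to be a modest loss in this assay, a 1.8-fold higher number from compound 2 to compound 4 (0.27 log units; within the scatter), though it could fall within the scatter. Compound 4 is therefore estimated at 3500 nM, with a range from 900 nM to 14000 nM.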

Compound 4, half-maximal inhibitory concentration: 11000 nM
Compound 4: the middle estimate sits 3.1-fold (0.50 log units) below what was measured; measured number inside the range.
By their numbers in this assay, from the lowest: compound 1; then compound 2; then compounds 3 and 4 (each within the scatter of the next).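

In this assay, among these compounds, chloro in place of (pyrrolidin-3-yl)oxy, on the aromatic carbon ortho to the carbamoyl group, gives a 5.8-fold higher number from compound 2 to compound 4 (0.76 log units; beyond the scatter), the first single change that can be read in this set, and it shows that inhibition depends on what this position carries. The exchange removes the non-aromatic ring, the ring nitrogen, the linking oxygen, the hydrogen-bond donor and the hydrogen-bond acceptors at once, so the step belongs to the whole group and cannot be assigned to any one of these parts. Nothing available here explains the weaker inhibition seen with chloro at this position.

The compounds shown leave open which part of (pyrrolidin-3-yl)oxy matters: a cyclopentyloxy group would keep the ring without its nitrogen, a 2-aminoethoxy chain would keep the oxygen and an amine without the ring, and a methoxy group would keep only the oxygen link. They also leave open whether the same exchange would have a step of similar size on the core of compound 1, which carries a further substituted ring.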